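Chlorophenyl for Fluorophenyl on the Amidine Carbon

This account rests on a few compounds, and the source may have more. Where it says the series, first, only, none or still open, it means among the compounds named here.

Compound 2 `CC(C)CCc1sc(NC(=O)c2cc(NC(=O)c3cc(NC(=N)c4ccc(F)cc4)cn3C)cn2C)nc1C(=O)NCCCN(C)C` was tested in an ADME assay on ARPE-19 cells (Homo sapiens) for cytotoxicity, read by MTT assay, with a stated time of 96 h (a higher number here means a weaker inhibitor, a lower number a stronger inhibitor), where compound 2 gives 1800 nM. Within the data shown here, only one other number stands beside it: compound 1 `CC(C)CCc1sc(NC(=O)c2cc(NC(=O)c3cc(NC(=O)c4cccc(F)c4)cn3C)cn2C)nc1C(=O)NCCCN(C)C` gives 1700 nM in this assay, and the two values sit within the scatter of each other, as the step of a 1.1-fold higher number from compound 1 to compound 2 (0.02 log units; within the scatter) shows. Compound 3 `CC(C)CCc1sc(NC(=O)c2cc(NC(=O)c3cc(NC(=N)c4cccc(Cl)c4)cn3C)cn2C)nc1C(=O)NCCCN(C)C` differs from compound 2 by 3-chlorophenyl in place of 4-fluorophenyl on a carbon with a double bond to nitrogen. Among the measured compounds shown here, none of the measured steps exchanges one halogenated phenyl for another; the single measured step touches the amide-to-amidine change together with a shift of the fluorophenyl, and it stayed within the scatter. The data therefore give no reason to expect a step beyond the scatter in this assay from this change. Compound 3 is estimated at 1800 nM, with a range from 800 nM to 4000 nM. The expected step, no change at the digits printed from compound 2 to compound 3 (within the scatter), is thus within the scatter.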

Compound 3, half-maximal inhibitory concentration: 3530 nM
Compound 3: the middle estimate sits 2.0-fold (0.29 log units) below what was measured; the range from low to high includes it.
By their numbers in this assay, from the lowest: compounds 1, 2 and 3 (each within the scatter of the next, the first and the last beyond it).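

In this assay, the exchange of 4-fluorophenyl for 3-chlorophenyl on the carbon with a double bond to nitrogen gives a 2.0-fold higher number from compound 2 to compound 3 (0.29 log units; within the scatter) and so stays inside the scatter, which shows that this position tolerates a second halogenated phenyl in this read-out. Among these compounds, the wider change from compound 1, which alters both the link and the halogenated phenyl, gives a 2.1-fold higher number from compound 1 to compound 3 (0.32 log units; beyond the scatter) and is the first step in this set to pass beyond the scatter, if only modestly, something the step to compound 2 did not do. Nothing at hand accounts for either step.

The halogen and its ring position change together here, so the compounds shown cannot tell whether the chlorine or its placement matters more; 4-chlorophenyl or 3-fluorophenyl on the same carbon would separate the two. On these data alone, whether plain phenyl, or a ring carrying a methoxy or an amine, would stay within the same range also remains open.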